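Methoxy removal in a pyrazolyl chalcone series

The compounds below may be only part of what the source reports. "The series", "measured", "known", "first", "only" and "open" are said of these compounds alone.

Compound 1 `COc1ccc(-c2cc(/C=C/C(=O)c3ccc(N)cc3)[nH]n2)cc1`, compound 2 `COc1ccc(-c2cc(/C=C/C(=O)c3ccc(N)cc3)[nH]n2)cc1OC` and compound 3 `COc1cc(C(=O)/C=C/c2cc(-c3cc(OC)c(OC)c(OC)c3)n[nH]2)cc(OC)c1OC` have been measured in a functional assay on ACHN cells (Homo sapiens) for cytotoxicity, read by sulforhodamine B assay, with a stated time of 48 h, tested at 100 uM; on this read-out lower numbers stand for a stronger effect and higher numbers for a weaker effect at the one concentration tested. Compound 1 gives -73%; compound 2 gives -95%; compound 3 gives -98%. The values of compound 2 and compound 3 lie within the scatter of each other. The change from compound 2 to compound 1, (hydrogen in place of methoxy on an aromatic carbon), made a step of a number 22 percentage points higher from compound 2 to compound 1 (beyond the scatter). How the core of compound 3 differs from that of compound 2 is not broken down here.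

Compound 4 `COc1ccc(-c2cc(/C=C/C(=O)c3cc(OC)c(OC)c(OC)c3)[nH]n2)cc1OC` has not been measured in this assay. It arises from compound 3 by hydrogen in place of methoxy on an aromatic carbon, the same kind of change as that from compound 2 to compound 1, though here the place is also meta to a methoxy group. Resting on the step from compound 2 to compound 1 of a number 22 percentage points higher from compound 2 to compound 1 (beyond the scatter), a step of a number 22 percentage points higher from compound 3 to compound 4 (beyond the scatter) is expected. Compound 4 is estimated at -76%, between -95% and -55%.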

Compound 4, a percentage reported as activity, at one concentration (the size of the read-out at that concentration, not a potency): -84%
For compound 4 the middle estimate is 8 percentage points above the measured one, and the stated range covers the measured number.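

In this assay, hydrogen in place of methoxy on an aromatic carbon gives a number 14 percentage points higher from compound 3 to compound 4 (beyond the scatter). The change therefore carries over between these two cores in direction, and the two steps do not differ in size beyond the scatter: the same change on two cores in this assay, a number 22 percentage points higher (beyond the scatter) from compound 2 to compound 1 and a number 14 percentage points higher (beyond the scatter) from compound 3 to compound 4, 8 percentage points apart, within the scatter of two such steps This rests on two pairs only, each read at a single concentration, so it says nothing about potency and gives no rule for other cores or for other places on the aromatic ring.

The compounds shown leave open whether hydroxyl or ethoxy in place of methoxy would read as hydrogen does. Also open, going by these compounds, is how a carboxylic acid in place of the amine on the core of compound 2 would read.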